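From compound 2 to compound 4: amide acyl group swap

The compounds below may be only part of what the source reports. "The series", "measured", "known", "first", "only" and "open" are said of these compounds alone.

For the measured compounds named here, in an assay on THP-1 cells for displacement of a labelled ligand from C-C chemokine receptor type 1 (Homo sapiens) (a higher number here means a weaker inhibitor, a lower number a stronger inhibitor), compound 2 `CC(C)[C@@H](NC(=O)c1nc2ccccc2s1)C(=O)N1CCC(c2ccc(Cl)cc2)CC1` gives 18 nM, the lowest of the three numbers measured so far. Compound 1 `CC[C@@H](NC(=O)c1ccccc1)C(=O)N1CCC(c2ccc(Cl)cc2)CC1` gives 121 nM in this assay, a gap beyond the scatter, and compound 3 `CC(C)C(NC(=O)c1ccccc1)C(=O)N1CCN(c2ccc(Cl)cc2)CC1` gives 525 nM, further still. Going by the values given here, neither compound 1 nor compound 3 differs from compound 2 in a single place, so no clean step between measured compounds is available.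

Compound 4 `CC(C)[C@@H](NC(=O)c1cc2ccccc2s1)C(=O)N1CCC(c2ccc(Cl)cc2)CC1` has not been measured. It differs from compound 2 in one place: 1-benzothiophen-2-yl in place of 1,3-benzothiazol-2-yl on a carbonyl carbon. The group that enters carries fewer hydrogen-bond acceptors than the group that leaves, while ring count and size are unchanged. Among the compounds with values here, no measured pair shows this change, so the size of the step is uncertain. A modest weakening is expected, a 2.2-fold higher number from compound 2 to compound 4 (0.35 log units; beyond the scatter), since compound 2 gives 18 nM and the change removes an acceptor. Compound 4 is therefore expected to give 40 nM in this assay, with a range of 12 nM to 130 nM.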

Compound 4, half-maximal inhibitory concentration: 58 nM
Beside the measured number, compound 4's estimate is 1.5-fold (0.16 log units) below it, and the stated range covers the measured number.
By their numbers in this assay, from the lowest: compound 2; then compound 4; then compound 1; then compound 3.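

In this assay the series now has its first step in a single place: a 3.2-fold higher number from compound 2 to compound 4 (0.51 log units; beyond the scatter) when 1-benzothiophen-2-yl replaces 1,3-benzothiazol-2-yl on a carbonyl carbon. The step is modest but beyond the scatter, so this position responds to the change of one ring atom, from nitrogen to carbon, even with ring count, ring size and heavy-atom count all unchanged. The step alone gives a size and a direction, and nothing at hand accounts for it.

Open, going by these compounds, is how other bicyclic groups on this carbonyl carbon would compare, such as 1,3-benzoxazol-2-yl or 1H-indol-2-yl, which would show whether the step is specific to this ring nitrogen. Also open, on these data alone, is whether the same swap gives a step of similar size on the core of compound 3.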